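The compounds below may be only part of what the source reports. "The series", "measured", "known", "first", "only" and "open" are said of these compounds alone.

Measured compounds:
compound 1 `CN(C)S(=O)(=O)c1ccc2nc(-c3ccc(-c4ccccc4F)cc3)[nH]c2c1`, 528 nM
compound 2 `CCS(=O)(=O)c1ccc2nc(-c3ccc(-c4ccccc4F)cc3)[nH]c2c1`, 1250 nM
compound 3 `CS(=O)(=O)c1ccc2nc(-c3ccc(-c4ccc(F)cc4)cc3)[nH]c2c1`, 25 nM

In an assay on isolated protein for inhibition of acyl-CoA desaturase 1 (Rattus norvegicus) (a lower number here means a stronger inhibitor, a higher number a weaker inhibitor), compound 3 gives the lowest number of the three; the numbers of compound 1 and compound 2 both lie well above it. Compound 4 `CS(=O)(=O)c1ccc2nc(-c3ccc(-c4ccccn4)cc3)[nH]c2c1` differs from compound 3 by pyridin-2-yl in place of 4-fluorophenyl on an aromatic carbon. Within the data shown here, the only measured step, a 2.4-fold higher number from compound 1 to compound 2 (0.37 log units; beyond the scatter), concerns a different place on the shared core and does not bear on this change; no measured pair varies the outer ring of the biaryl. The expectation therefore rests on compound 3 alone, with wide uncertainty and a guarded lean toward a somewhat higher number, a 3.0-fold higher number from compound 3 to compound 4 (0.48 log units; beyond the scatter). Compound 4 is estimated at 75 nM, range 20 nM to 300 nM.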

Compound 4, half-maximal inhibitory concentration: 1710 nM
Compound 4: middle estimate off by 23-fold (1.36 log units), on the low side; the whole stated range lies below it.
By their numbers in this assay, from the lowest: compound 3; then compound 1; then compounds 2 and 4 (each within the scatter of the next).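

Among these compounds, this position is far from tolerant of change in this assay: on an aromatic carbon para to a large group, the swap gives a 68-fold higher number from compound 3 to compound 4 (1.84 log units; beyond the scatter), a much larger step than the one earlier step at the sulfonyl sulfur, a 2.4-fold higher number from compound 1 to compound 2 (0.37 log units; beyond the scatter). The swap adds a ring nitrogen and removes the fluorine at once, so the two changes cannot be separated here. Nothing available accounts for the size of the step.

Open, on these data alone, is whether unsubstituted phenyl would stay near compound 3 or fall near compound 4. Also open, as far as these compounds go, is whether pyridin-3-yl or pyridin-4-yl would behave as pyridin-2-yl does.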